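The compounds below may be only part of what the source reports. "The series", "measured", "known", "first", "only" and "open" are said of these compounds alone.

Measured in a functional assay on DU-145 cells (Homo sapiens) for inhibition, read by trypan blue exclusion, with a stated time of 96 h; a lower number here means a stronger inhibitor of growth, a higher number a weaker inhibitor of growth:
- Compound 1 (`Cc1ccc(S/C(=C/c2ccc(Br)cc2)C(=O)c2ccc(Cl)cc2)cc1`): 25000 nM
- Compound 2 (`COc1ccccc1/C=C(\C(=O)c1ccc(Cl)cc1)S(=O)(=O)Cc1ccc(Cl)c(Cl)c1`): 1000 nM
- Compound 3 (`Cc1ccc(S/C(=C/c2ccc(N(C)C)cc2)C(=O)c2ccc(Cl)cc2)cc1`): > 100000 nM, a limit and not a number

Compound 3 has only a limit in this assay: the limit of > 100000 nM in this assay, at which 1 of the 3 values shown sits.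

Next comes compound 4 (`Cc1ccc(S/C(=C/c2cc(Cl)cc(Cl)c2Cl)C(=O)c2ccc(Cl)cc2)cc1`), with this change: 2,3,5-trichlorophenyl in place of 4-(dimethylamino)phenyl on a double-bonded chain carbon bound to a double-bonded chain carbon.

Among the compounds with values here, the one measured step that bears on it is an at least 4.0-fold higher number from compound 1 to compound 3 (0.60 log units; beyond the scatter), beyond the scatter. Read in reverse, it points to a lower number when the 4-(dimethylamino)phenyl is replaced by a halogen-bearing ring, with compound 1 at 25000 nM as the nearest anchor. Within the data shown here, compound 2 offers no single-place step.

The expected step is an at least 6.6-fold lower number from compound 3 to compound 4 (0.82 log units; beyond the scatter), toward stronger inhibition of growth.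

Compound 4 is estimated at 15000 nM, with an expected range of 4000 nM to 50000 nM.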

Compound 4, concentration for 50% growth inhibition: 50000 nM
Compound 4: middle estimate off by 3.3-fold (0.52 log units), on the low side; the range from low to high includes it.
By their numbers in this assay, from the lowest: compound 2; then compounds 1 and 4 (each within the scatter of the next). At a limit, above all of these: compound 3.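

In this assay the change from 4-(dimethylamino)phenyl to 2,3,5-trichlorophenyl at this place reads as an at least 2.0-fold lower number from compound 3 to compound 4 (0.30 log units; that floor lies within the scatter) and so gives only a floor. Compound 3 stands at a limit and not at a number: the limit of > 100000 nM in this assay, at which 1 of the 4 values shown sits. The change from 4-bromophenyl to 2,3,5-trichlorophenyl reads as a 2.0-fold higher number from compound 1 to compound 4 (0.30 log units; within the scatter) and so does not separate the two halogen-bearing rings.

Still open, going by these compounds, is how a nitrile or a carboxylic acid on this ring would read in this assay on the same core. A ring with a single chlorine would show whether the number of chlorines matters here.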